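Piperazine Changes on a Shared Core at the Assay Limit

The source may report more compounds than this note shows. Statements on the series, on what has been measured and on what is new or still open speak of the compounds shown alone.

Compound 1 `CN(C[C@H]1Cc2c(cccc2N2CCN(C3COC3)CC2)CN1)[C@H]1CCCc2cccnc21` gives > 30000 nM in a functional assay on CCRF-CEM cells for agonist activity at C-X-C chemokine receptor type 4 (Homo sapiens), read by calcium flux, with a stated time of 25 min; a higher number here means that more compound is needed for the effect, a lower number that less compound is needed.
Compound 2 `C[C@@H]1CN(c2cccc3c2C[C@H](CN(C)[C@H]2CCCc4cccnc42)NC3)C[C@H](C)N1` gives > 30000 nM in this assay.
Compound 3 `CN(C[C@H]1Cc2c(cccc2N2CCN(C3CC3)CC2)CN1)[C@H]1CCCc2cccnc21` gives > 30000 nM in this assay.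

Each of these values is a limit of the assay and not a number; for compound 3 the value > 30000 nM is such a limit, and the same holds for compound 1 and for compound 2. All three sit at the same place, as the limit of > 30000 nM in this assay, at which 3 of the 3 values shown sit, records. The steps between them, a step that the two limits leave unreadable from compound 1 to compound 2, a step that the two limits leave unreadable from compound 1 to compound 3 and a step that the two limits leave unreadable from compound 2 to compound 3, therefore cannot be read in size or direction.

Compound 4 `CN(C[C@H]1Cc2c(cccc2N2CCNC(C)(C)C2)CN1)[C@H]1CCCc2cccnc21` differs from compound 3 in one place: 3,3-dimethylpiperazin-1-yl in place of 4-cyclopropylpiperazin-1-yl on an aromatic carbon. Going by the values given here, the step from compound 2 to compound 3 also exchanges a dimethylpiperazinyl group for a cyclopropylpiperazinyl group, yet it is unreadable, so no measured step shows a size for the change at hand. Compound 4 is therefore expected to sit at the limit as well, with the expected step that the limit leaves unreadable from compound 3 to compound 4 carrying no readable direction. The estimate for compound 4 is 40000 nM, within 15000 nM to 100000 nM.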

Compound 4, half-maximal effective concentration: > 30000 nM
Compound 4: no number, only a limit; the forecaster's own chance of this, stated with the estimate: 80%; the middle value does not contradict the limit.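

In this assay compound 4 gives > 30000 nM, a limit and not a number. Its steps to compound 1, compound 2 and compound 3 cannot be read, as all four compounds sit at one place: the limit of > 30000 nM in this assay, at which 4 of the 4 values shown sit.

The compounds shown leave open which piperazine group, if any, on the shared core would give a measurable value in this assay.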